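Methoxy to hydroxy on the aryl arm: compound 4

The source may report more compounds than this note shows. Statements on the series, on what has been measured and on what is new or still open speak of the compounds shown alone.

Compound 1 `COc1cc(C)cc(-c2nn(CC#N)cc2-c2ccc(-c3cccc(C(C)=O)c3)nc2)c1`: 85%
Compound 2 `Cc1cc(O)cc(-c2nn(CC#N)cc2-c2ccnc(-c3ccc(Oc4ccccc4)cc3)c2)c1`: 83%
Compound 3 `COc1cc(C)cc(-c2nn(CC#N)cc2-c2ccnc(-c3ccc(N(C)C)cc3)c2)c1`: 77%

In a functional assay on NCI-H522 cells (Homo sapiens) for cytotoxicity, read by sulforhodamine B assay, with a stated time of 48 h, tested at 0.001 uM (a lower number here means a stronger effect, a higher number a weaker effect of the compound at the concentration tested), compound 1 gives 85%, compound 2 gives 83% and compound 3 gives 77%. All three numbers sit high, so none of the compounds shows much effect at this concentration. Compound 3 reads the smallest of the three, but its gap to compound 2 and its gap to compound 1 both lie within the scatter, so the three cannot be told apart.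

Compound 4 `Cc1cc(O)cc(-c2nn(CC#N)cc2-c2ccnc(-c3ccc(N(C)C)cc3)c2)c1` is not yet measured. Relative to compound 3 the difference is hydrogen in place of methyl on an oxygen on an aromatic ring. Compound 2 already carries a hydroxy group in place of methoxy, paired with a different aryl on the other side of the core, and its number is indistinguishable from that of compound 3. Among the measured compounds shown here, no pair of measured compounds isolates this single change, so no measured step can be quoted for it.

For compound 4 the step of a number 2 percentage points higher from compound 3 to compound 4 (within the scatter) is expected to be small, with no movement beyond the scatter in either direction. Compound 4 is therefore estimated at 79%, in the range 66% to 92%.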

Compound 4, a percentage reported as activity, at one concentration (the size of the read-out at that concentration, not a potency): 87%
Beside the measured number, compound 4's estimate is 8 percentage points below it, within the range that was stated.
By their numbers in this assay, from the lowest: compounds 3, 2, 1 and 4 (each within the scatter of the next).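

In this assay the change from methoxy to hydroxy on the aryl arm can now be read directly: a number 10 percentage points higher from compound 3 to compound 4 (within the scatter) shows that hydrogen in place of methyl on this oxygen gives no difference that can be separated from the scatter at the one concentration tested. With the hydroxy group held constant, dimethylamino in place of phenoxy on an aromatic carbon can also be read directly, and a number 4 percentage points higher from compound 2 to compound 4 (within the scatter) likewise gives no separable difference. No measured property of these compounds bears on either step, so the data offer no explanation for these readings.

All four values sit high, which leaves open whether the change from methoxy to hydroxy would separate at a concentration where the compounds have a larger effect. Also open, on these data alone, is whether an ethyl group or a longer chain on this oxygen, or a carboxylic acid or a primary amine in place of the dimethylamino group, would move the number beyond the scatter.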